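The compounds below may be only part of what the source reports. "The series", "measured", "known", "first", "only" and "open" are said of these compounds alone.

Of the compounds shown here, three built on one shared core have been measured in an assay on CHO cells for displacement of a labelled ligand from 5-hydroxytryptamine receptor 1D (Homo sapiens); on this read-out lower numbers stand for stronger inhibition and higher numbers for weaker inhibition. Compound 1 `CN(Cc1ccccc1)CC1CCN(CCCc2c[nH]c3ccc(-n4cnnc4)cc23)CC1` gives 0.9 nM. Compound 2 `CC(=O)Nc1ccc([C@H](C)NCC2CCN(CCCc3c[nH]c4ccc(-n5cnnc5)cc34)CC2)cc1` gives 0.6 nM. Compound 3 `CN(CC1CCN(CCCc2c[nH]c3ccc(-n4cnnc4)cc23)CC1)C(=O)Nc1ccccc1` gives 5.9 nM, the highest of the three numbers: compound 1 stands nearest to it and compound 2 furthest, both with gaps beyond the usual scatter. Only one measured step joins two of these compounds in a single change: a 6.6-fold higher number from compound 1 to compound 3 (0.82 log units; beyond the scatter).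

Compound 4 `c1ccc2c(c1)CCC2NCC1CCN(CCCc2c[nH]c3ccc(-n4cnnc4)cc23)CC1` has not yet been measured. Against compound 3 its change is (2,3-dihydro-1H-inden-1-yl)amino in place of methyl(phenylcarbamoyl)amino on a saturated chain carbon bound to a saturated ring carbon. The step from compound 1 to compound 3 bears on this, since it showed that introducing phenylcarbamoyl in place of benzyl raised the number; compound 4 removes the phenylcarbamoyl again and, like compound 2, carries a hydrogen-bond donor at that nitrogen. The number is therefore expected to fall back toward those of compound 1 and compound 2, by about a 4.9-fold lower number from compound 3 to compound 4 (0.69 log units; beyond the scatter). For compound 4 the estimate in this assay is 1.2 nM, within a range from 0.4 nM to 4 nM.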

Compound 4, half-maximal inhibitory concentration: 1.1 nM
Compound 4: the middle estimate sits 1.1-fold (0.04 log units) above what was measured; the measured number falls inside the stated range.
By their numbers in this assay, from the lowest: compounds 2, 1 and 4 (each within the scatter of the next); then compound 3.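

In this assay, (2,3-dihydro-1H-inden-1-yl)amino in place of methyl(phenylcarbamoyl)amino on a saturated chain carbon bound to a saturated ring carbon gives a 5.4-fold lower number from compound 3 to compound 4 (0.73 log units; beyond the scatter), so the shared core does not itself hold the number at the level of compound 3. This place also accepts quite different groups with no clear change in the number: the comparisons give a 1.2-fold higher number from compound 1 to compound 4 (0.09 log units; within the scatter) and a 1.8-fold higher number from compound 2 to compound 4 (0.26 log units; within the scatter), both within the usual scatter. Among these four compounds, only compound 3, with its phenylcarbamoyl group, stands apart from the rest.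

Nothing available explains why this group goes with a higher number. Still open, on these data alone, is how an acetyl or methanesulfonyl group on that amine nitrogen, or a plain primary amine at this place, would read in this assay.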